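Removing the ring fluorine from compound 1

This account rests on a few compounds, and the source may have more. Where it says the series, first, only, none or still open, it means among the compounds named here.

Compound 1 `O=C(C1COc2ccccc2O1)N1N=C(c2ccc(Br)cc2)CC1c1ccccc1F` gives the highest number of the three compounds measured in a functional assay on WM 266-4 cells (Homo sapiens) for inhibition, read by MTT assay, with a stated time of 24 h (a higher number here means a weaker inhibitor of growth, a lower number a stronger inhibitor of growth), at 8030 nM. Compound 2 `O=C(C1COc2ccccc2O1)N1N=C(c2ccccc2)CC1c1ccc(F)cc1` gives 3270 nM in this assay, and compound 3 `O=C(c1ccc2c(c1)OCCO2)N1N=C(c2ccc(Br)cc2)CC1c1ccccc1F` gives 580 nM. Going by the values given here, the one step measured between compounds differing in a single place is a 14-fold lower number from compound 1 to compound 3 (1.14 log units; beyond the scatter), a change at the carbonyl that says nothing about the aromatic ring carrying the fluorine. Compound 2 differs from compound 1 in two places, so its value alone cannot be traced to either one.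

Compound 4 `O=C(C1COc2ccccc2O1)N1N=C(c2ccc(Br)cc2)CC1c1ccccc1` differs from compound 1 by hydrogen in place of fluoro on an aromatic carbon. Among the compounds with values here, no measured step covers this change; the single fluorine is a small removal, and the account therefore expects compound 4 to stay close to compound 1 in this assay, with a step of a 1.1-fold lower number from compound 1 to compound 4 (0.06 log units; within the scatter) that may well fall inside the scatter. Compound 4 is estimated at 7000 nM, within a range from 2500 nM to 20000 nM.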

Compound 4, concentration for 50% growth inhibition: 6150 nM
Beside the measured number, compound 4's estimate is 1.1-fold (0.06 log units) above it, and the stated range covers the measured number.
By their numbers in this assay, from the lowest: compound 3; then compounds 2, 4 and 1 (each within the scatter of the next, the first and the last beyond it).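

The fluoro on the aromatic carbon ortho to a large group now has a measured step of its own: in this assay, hydrogen in its place gives a 1.3-fold lower number from compound 1 to compound 4 (0.12 log units; within the scatter), which lies within the scatter. With the 2,3-dihydro-1,4-benzodioxin-2-yl group on the carbonyl, 2-fluorophenyl and phenyl therefore cannot be told apart in this assay, whereas the change at the carbonyl gives a 14-fold lower number from compound 1 to compound 3 (1.14 log units; beyond the scatter), beyond the scatter. Nothing available explains why the fluoro counts for so little here.

As far as these compounds go, whether a methoxy group or an amine at this same place would shift the number remains open. From the compounds shown here alone, it is also open whether 2-fluorophenyl to phenyl would read the same on the carbonyl group of compound 3.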